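The source may report more compounds than this note shows. Statements on the series, on what has been measured and on what is new or still open speak of the compounds shown alone.

Series notes. Compound 1 `CN(C)CCn1cnnc1-c1cc(Oc2ccc(NC(=O)N/N=C/c3c(Cl)cccc3Cl)cc2F)ccn1` gives 1410 nM in a functional assay on A549 cells (Homo sapiens) for cytotoxicity, read by MTT assay, with a stated time of 72 h; on this read-out lower numbers stand for stronger inhibition and higher numbers for weaker inhibition. Compound 2 `CN(C)CCn1cnnc1-c1cc(Oc2ccc(NC(=O)N/N=C/c3c[nH]c4ccccc34)cc2F)ccn1` gives 820 nM in this assay, and compound 3 `COc1ccc(/C=N/NC(=O)Nc2ccc(Oc3ccnc(-c4nncn4CCN(C)C)c3)c(F)c2)c(OC)c1OC` gives 6680 nM in this assay. Compound 3 carries the highest number of the three: the steps are a 4.7-fold higher number from compound 1 to compound 3 (0.68 log units; beyond the scatter) and an 8.1-fold higher number from compound 2 to compound 3 (0.91 log units; beyond the scatter), both beyond the scatter, whereas a 1.7-fold lower number from compound 1 to compound 2 (0.24 log units; within the scatter) stays within it. Compound 4 `CN(C)CCn1cnnc1-c1cc(Oc2ccc(NC(=O)N/N=C/c3ccccc3O[N+](=O)[O-])cc2F)ccn1` is not yet measured; its difference from compound 3 is 2-(nitrooxy)phenyl in place of 2,3,4-trimethoxyphenyl on a carbon with a double bond to nitrogen. The measured steps that bear on this place show the 2,3,4-trimethoxyphenyl group at the high end, with the 2,6-dichlorophenyl and 1H-indol-3-yl variants giving lower numbers by modest margins. No group with a nitrooxy substituent has been measured at this place, so the size of the step can only be bracketed by the range already seen. A moderate move downward is expected in this assay, the estimated step being a 2.7-fold lower number from compound 3 to compound 4 (0.43 log units; beyond the scatter). Compound 4 is therefore expected at 2500 nM, within 900 nM to 7000 nM.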

Compound 4, half-maximal inhibitory concentration: 1200 nM
For compound 4 the middle estimate is 2.1-fold (0.32 log units) above the measured one, within the range that was stated.
By their numbers in this assay, from the lowest: compounds 2, 4 and 1 (each within the scatter of the next); then compound 3.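

The 2-(nitrooxy)phenyl group brings a nitrooxy substituent to this place, on a carbon with a double bond to nitrogen, and in this assay replacing the 2,3,4-trimethoxyphenyl group gives a 5.6-fold lower number from compound 3 to compound 4 (0.75 log units; beyond the scatter). Against the two other groups the change stays within the scatter, with a 1.5-fold higher number from compound 2 to compound 4 (0.17 log units; within the scatter) and a 1.2-fold lower number from compound 1 to compound 4 (0.07 log units; within the scatter), so three different groups now fall together and compound 3 alone stands apart among these four compounds. Nothing available explains this separation.

Open, on these data alone, is whether the nitrooxy substituent itself matters, or whether a plain phenyl, a hydroxyphenyl or an aminophenyl group at this place would give a similar number. Also open, as far as these compounds go, is whether a single methoxy group on the phenyl ring would give a number like that of compound 3 or like those of the other three.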